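Chromone dithiocarbamates: ring amine variation on the thiocarbonyl carbon

A few compounds are considered here, and "the series" means these few. Any claim that something is new, unique, unknown or untested is made for them only; others in the source may bear on it.

Measured so far:
compound 1 `O=c1c(CSC(=S)N2CCOCC2)coc2cc(Cl)ccc12` — 8100 nM
compound 2 `O=c1c(CSC(=S)N2CCCCC2)coc2cc(Cl)ccc12` — 380 nM

For the measured compounds named here, in a functional assay on MCF7 cells (Homo sapiens) for antiproliferative activity, read by MTT assay, with a stated time of 72 h (a lower number here means a stronger inhibitor, a higher number a weaker inhibitor), compound 2 stands lowest of the two numbers; the only other measured compound, compound 1, gives 8100 nM, and the step of a 21-fold lower number from compound 1 to compound 2 (1.33 log units; beyond the scatter) separates them. Going by the values given here, that single step changes the amine on the thiocarbonyl carbon and is the only evidence on what this position tolerates.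

Compound 3 `O=c1c(CSC(=S)N2CCCC2)coc2cc(Cl)ccc12` takes the next step at the same place: pyrrolidin-1-yl in place of piperidin-1-yl on a thiocarbonyl carbon. Among the compounds with values here, the one measured step bears on it only loosely. It shows that the amine on the thiocarbonyl carbon can move the number a great deal, but it swaps one hetero atom pattern for another rather than contracting the ring, so it does not tell the direction for compound 3. Within the data shown here, with no closer precedent, the expected step of a 1.3-fold higher number from compound 2 to compound 3 (0.12 log units; within the scatter) is small and may fall within the scatter, with a wide range in both directions.

For compound 3 the estimate in this assay is 500 nM, expected between 150 nM and 2000 nM.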

Compound 3, half-maximal inhibitory concentration: 600 nM
Estimate against measurement, compound 3: 1.2-fold (0.08 log units) below, and the stated range covers the measured number.
By their numbers in this assay, from the lowest: compounds 2 and 3 (each within the scatter of the next); then compound 1.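

In this assay, contracting the ring from piperidin-1-yl to pyrrolidin-1-yl on the thiocarbonyl carbon gives a 1.6-fold higher number from compound 2 to compound 3 (0.20 log units; within the scatter), so this position accepts either ring size and the two amines cannot be ordered. The second step away from morpholin-4-yl, a 14-fold lower number from compound 1 to compound 3 (1.13 log units; beyond the scatter), shows that the large separation from compound 1 is not peculiar to piperidin-1-yl: compound 2 and compound 3 both stand well clear of it, and among these three amines morpholin-4-yl is the only one carrying a ring oxygen. No measured evidence accounts for either step.

From the compounds shown here alone, whether the ring oxygen itself sets compound 1 apart remains open, and a piperazin-1-yl or thiomorpholin-4-yl ring on the same carbon would test how far that separation depends on the identity of the second ring hetero atom. Also unresolved is whether a ring is needed at all and how much room the position has, questions that an open-chain diethylamino group, the larger azepan-1-yl ring or a 4-methylpiperidin-1-yl group would address.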